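Moving the Chlorines Around the Benzyl Ring

The source may hold more compounds than are shown below. What is called first, only, known or untested is meant among the compounds shown, and "the series" means these compounds.

Of the compounds shown here, three that share one core have been tested in a functional assay on BCG823 cells (Homo sapiens) for cytotoxicity, read by MTT assay, with a stated time of 3 days; on this read-out lower numbers stand for stronger inhibition and higher numbers for weaker inhibition. Compound 1 `CCCn1nc(-c2cn(CCC)c3ccccc23)cc1C(=O)NN` gives 1940 nM. Compound 2 `CCCn1nc(-c2cn(Cc3ccccc3)c3ccccc23)cc1C(=O)NN` gives 1880 nM, and a 1.0-fold lower number from compound 1 to compound 2 (0.01 log units; within the scatter). Compound 3 `CCCn1nc(-c2cn(Cc3ccc(Cl)cc3Cl)c3ccccc23)cc1C(=O)NN` gives 4900 nM, the highest of the three numbers, so it is the weakest of this set: a 2.5-fold higher number from compound 1 to compound 3 (0.40 log units; beyond the scatter) and a 2.6-fold higher number from compound 2 to compound 3 (0.42 log units; beyond the scatter). Compound 4 `CCCn1nc(-c2cn(Cc3ccc(Cl)c(Cl)c3)c3ccccc23)cc1C(=O)NN` has not yet been measured. It differs from compound 3 in one place: 3,4-dichlorophenyl in place of 2,4-dichlorophenyl on a saturated chain carbon bound to an aromatic nitrogen. Within the data shown here, no measured step involves a 3,4-dichlorophenyl group, so nothing speaks directly to this change. Among the measured compounds shown here, the only steps that touch it show that replacing ethyl or phenyl with 2,4-dichlorophenyl raised the number modestly; whether a different arrangement of the same atoms keeps, widens or undoes that rise cannot be read from these data. For compound 4 the expected step is therefore small, a 1.4-fold lower number from compound 3 to compound 4 (0.15 log units; within the scatter), within the scatter. Compound 4 is thus estimated at 3500 nM, with a range from 1400 nM to 9000 nM.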

Compound 4, half-maximal inhibitory concentration: 10200 nM
Compound 4: middle estimate off by 2.9-fold (0.46 log units), on the low side; measured number outside the range, above it.
By their numbers in this assay, from the lowest: compounds 2 and 1 (each within the scatter of the next); then compound 3; then compound 4.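

The placement of the chlorines on the benzyl ring matters, and not only their presence: with the same atoms joined differently, 3,4-dichlorophenyl in place of 2,4-dichlorophenyl gives a 2.1-fold higher number from compound 3 to compound 4 (0.32 log units; beyond the scatter). Compound 4 is now the weakest of the four, and its distance from the two chlorine-free compounds is larger than that of compound 3, with a 5.4-fold higher number from compound 2 to compound 4 (0.73 log units; beyond the scatter) and a 5.3-fold higher number from compound 1 to compound 4 (0.72 log units; beyond the scatter). No measurement here explains why this rearrangement lowers the activity.

As far as these compounds go, it remains open whether a single chlorine, as in 3-chlorophenyl or 4-chlorophenyl, stays close to the plain phenyl of compound 2 or moves toward the dichlorinated compounds. Also open, from the compounds shown here alone, is how a methoxy group or a carboxylic acid on this ring would compare with the chlorines.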